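The compounds below may be only part of what the source reports. "The series", "measured", "known", "first", "only" and "open" are said of these compounds alone.

Measured compounds:
- compound 1 `CCOc1ccc(-c2nn3cc(-c4cccc(N)c4)nc3s2)cc1` — 94000 nM
- compound 2 `C=C(Br)C(=O)Nc1cccc(-c2cn3nc(-c4ccc(OCC)cc4)sc3n2)c1` — 1100 nM
- compound 3 `C=C(Br)C(=O)Nc1cccc(-c2cn3c(-c4ccc(Cl)cc4)csc3n2)c1` — 3000 nM

In a functional assay on HeLa cells (Homo sapiens) for inhibition, read by cell counting, with a stated time of 4 days (a higher number here means a weaker inhibitor, a lower number a stronger inhibitor), compound 2 holds the lowest of the three numbers; compound 3 sits nearest, compound 1 furthest, both beyond the scatter. Among the compounds with values here, the one step that differs in a single place, an 85-fold lower number from compound 1 to compound 2 (1.93 log units; beyond the scatter), concerns the (1-bromoethenyl)carbonyl on the ring nitrogen, which compound 4 keeps. Compound 4 `C=C(Br)C(=O)Nc1cccc(-c2cn3nc(CCc4ccccc4)sc3n2)c1` instead alters the other end: phenethyl in place of 4-ethoxyphenyl on an aromatic carbon. Within the data shown here, no measured pair isolates a change at this carbon, and compound 3 differs from compound 2 in more than one place, so its value only shows that a different aryl group on an altered core still gives a number in the low micromolar range. Among the measured compounds shown here, replacing the aryl group with a phenethyl chain has no precedent here; a moderate rise in the number is expected for compound 4, though the direction is uncertain. The expected step is a 2.7-fold higher number from compound 2 to compound 4 (0.44 log units; beyond the scatter). Compound 4 is therefore estimated at 3000 nM, with a range of 800 nM to 12000 nM in this assay.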

Compound 4, half-maximal inhibitory concentration: 3300 nM
Compound 4: the middle estimate sits 1.1-fold (0.04 log units) below what was measured; low and high end bracket the measured number.
By their numbers in this assay, from the lowest: compound 2; then compounds 3 and 4 (each within the scatter of the next); then compound 1.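

In this assay, this aromatic carbon of the shared core now has its first single-place comparison: a 3.0-fold higher number from compound 2 to compound 4 (0.48 log units; beyond the scatter). Compound 4, at 3300 nM, shows that the number at this carbon responds to the group placed there, although the step is modest beside the one at the ring nitrogen, an 85-fold lower number from compound 1 to compound 2 (1.93 log units; beyond the scatter). The step swaps 4-ethoxyphenyl for phenethyl as a whole, so it cannot separate the loss of the ethoxy oxygen from the change in how the carbon-only ring is attached, and nothing available explains the higher number.

The compounds shown leave open how a plain phenyl, a benzyl, an amine or a longer chain at this carbon would read in this assay. Also open, going by these compounds, is whether phenethyl gives a similar step when the (1-bromoethenyl)carbonyl is absent.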